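The compounds below may be only part of what the source reports. "The series", "measured", "known", "first", "only" and "open" are said of these compounds alone.

Working notes on the series. Compound 1 `C=CCONC(=O)CN1C(=O)S/C(=C\c2cccc(C(=O)N[C@@H](CC(C)C)C(=O)OC)c2)C1=O`, compound 2 `COC(=O)[C@H](CC(C)C)NC(=O)c1cccc(/C=C2\SC(=O)N(CC(=O)NOCc3ccccc3)C2=O)c1` and compound 3 `C=CCONC(=O)CN1C(=O)S/C(=C\c2ccc(C(=O)N[C@H](C(=O)OC)C(C)C)cc2)C1=O` have been run in a functional assay on MRC5 cells (Homo sapiens) for inhibition, read by microscopy and resazurin assay, with a stated time of 72 h (on this read-out lower numbers stand for stronger inhibition and higher numbers for weaker inhibition), while compound 4 `COC(=O)[C@@H](NC(=O)c1ccc(/C=C2\SC(=O)N(CC(=O)NOCc3ccccc3)C2=O)cc1)C(C)C` has not. In this assay compound 1 gives only a limit of the assay, > 128000 nM. For compound 2 the result is likewise a limit, > 128000 nM. Compound 3 also returns a limit, > 128000 nM. The change from compound 1 to compound 2 is phenyl in place of vinyl on a saturated chain carbon bound to an oxygen on an unsaturated carbon; its size is a step that the two limits leave unreadable from compound 1 to compound 2. The same change is to be made from compound 3 to compound 4, (phenyl in place of vinyl on a saturated chain carbon bound to an oxygen on an unsaturated carbon); how the core of compound 1 and the core of compound 3 differ is not broken down here. Because (the limit of > 128000 nM in this assay, at which 3 of the 3 values shown sit), with every measured compound of the series sitting there, the step in this assay is expected to be a step that the limit leaves unreadable from compound 3 to compound 4, set beside the earlier unreadable one. Compound 4 is accordingly estimated at 200000 nM, most probably again reported only as a limit, within a range of 100000 nM to 600000 nM.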

Compound 4, half-maximal inhibitory concentration: > 128000 nM
Compound 4 ended at the assay's limit (the forecaster's own chance of this, stated with the estimate: 85%); the middle value lies beyond the limit too.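

No size can be read for the step from compound 3 to compound 4, and the series stays where it stood: the limit of > 128000 nM in this assay, at which 4 of the 4 values shown sit. The compounds shown leave open whether the change from allyloxy to benzyloxy, or the difference between the core of compound 1 and the core of compound 3, has any effect on the read-out in this assay.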